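Methyl in place of fluoro: from compound 3 to compound 4

A few compounds are considered here, and "the series" means these few. Any claim that something is new, unique, unknown or untested is made for them only; others in the source may bear on it.

For the measured compounds named here, the three measured members share one core and differ only in the group on an amine nitrogen in a ring. Compound 1 `Nc1ccccc1NC(=O)c1ccc(CSC(=S)N2CCN(c3ccccc3)CC2)cc1` gives 88.6% in a functional assay on A-375 cells (Homo sapiens) for antiproliferative activity, read by CCK-8 assay, with a stated time of 72 h, tested at 8 uM; a lower number here means a weaker effect, a higher number a stronger effect of the compound at the concentration tested. Compound 2 `Nc1ccccc1NC(=O)c1ccc(CSC(=S)N2CCN(c3cccnc3)CC2)cc1` gives 88.8% in the same assay; the pair differs by a number 0.2 percentage points higher from compound 1 to compound 2 (within the scatter). Compound 3 `Nc1ccccc1NC(=O)c1ccc(CSC(=S)N2CCN(c3ccc(F)cc3)CC2)cc1` gives 76.3% and stands lowest of the three, with a number 12.3 percentage points lower from compound 1 to compound 3 (beyond the scatter) and a number 12.5 percentage points lower from compound 2 to compound 3 (beyond the scatter).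

Compound 4 `Cc1ccc(N2CCN(C(=S)SCc3ccc(C(=O)Nc4ccccc4N)cc3)CC2)cc1` is not yet measured. It differs from compound 3 by methyl in place of fluoro on an aromatic carbon.

Going by the values given here, the only measured step touching that aromatic carbon is the one from compound 1 to compound 3, where fluoro in place of hydrogen gave a number 12.3 percentage points lower from compound 1 to compound 3 (beyond the scatter). Among the compounds with values here, no measured pair shows a methyl at that carbon, so the direction of the change for compound 4 rests on the fact that the fluoro, the one group that lowered the number, is removed. A modest rise back toward the values of compound 1 and compound 2 is therefore expected, though a result within the scatter of compound 3 cannot be excluded.

Compound 4 is expected to give about 83% in this assay, between 70% and 92%, an estimated step of a number 6.7 percentage points higher from compound 3 to compound 4 (within the scatter).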

Compound 4, a percentage reported as inhibition, at one concentration (the size of the read-out at that concentration, not a potency): 26.4%
Beside the measured number, compound 4's estimate is 56.6 percentage points above it; the whole stated range lies above it.
By their numbers in this assay, from the lowest: compound 4; then compound 3; then compounds 1 and 2 (each within the scatter of the next).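

At the aromatic carbon para to a large group, exchanging one heavy atom for another, with no change in hydrogen-bond donors, hydrogen-bond acceptors or net charge, gives a number 49.9 percentage points lower from compound 3 to compound 4 (beyond the scatter) in this assay, so this position tolerates far less than the modest fluoro step had suggested. Methyl in place of hydrogen gives a number 62.2 percentage points lower from compound 1 to compound 4 (beyond the scatter), whereas fluoro in place of hydrogen gives only a number 12.3 percentage points lower from compound 1 to compound 3 (beyond the scatter); 4-methylphenyl in place of pyridin-3-yl likewise gives a number 62.4 percentage points lower from compound 2 to compound 4 (beyond the scatter), so the identity of the group at this carbon matters much more than the earlier compounds showed. No measurement at hand speaks to what lies behind this large drop.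

As far as these compounds go, it remains open whether the loss is particular to methyl or extends to other groups at this carbon, and a chloro, methoxy, ethyl or trifluoromethyl group there would help separate those readings. From the compounds shown here alone, since the read-out comes from one concentration, it also remains open how the gap between these compounds would appear across a full concentration range.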